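Methoxy for hydroxy on the aryl tail of a piperazine amide

The compounds below may be only part of what the source reports. "The series", "measured", "known", "first", "only" and "open" are said of these compounds alone.

Measured compounds:
compound 1, `CC[C@H](C)C(N)c1cc(C(F)(F)F)ccc1N1CCN(C(=O)CCc2ccc(Cl)cc2Cl)CC1`, 75 nM in an assay on HEK293 cells for displacement of a labelled ligand from Melanocortin receptor 4 (Homo sapiens); a lower number here means a stronger inhibitor, a higher number a weaker inhibitor
compound 2, `CC(C)C[C@H](N)c1cc(C(F)(F)F)ccc1N1CCN(C(=O)CCc2ccccc2O)CC1`, 3300 nM in this assay

Compound 2 stands at the higher of the two numbers in this assay; compound 1 reaches a far lower number, and the gap between the two lies well beyond the scatter. The two compounds differ in more than one place, so their values are simply set side by side here. Compound 3, `COc1cccc(CCC(=O)N2CCN(c3ccc(C(F)(F)F)cc3[C@@H](N)CC(C)C)CC2)c1`, has not been measured. It differs from compound 2 by 3-methoxyphenyl in place of 2-hydroxyphenyl on a saturated chain carbon, two bonds along the chain from a carbonyl carbon. For the measured compounds named here, no step between measured compounds covers this change, so the expectation rests on compound 2 alone. A step of modest size toward a lower number is expected, a 2.2-fold lower number from compound 2 to compound 3 (0.34 log units; beyond the scatter), near the edge of the scatter rather than clearly beyond it. Compound 3 is therefore estimated at 1500 nM, within a range from 400 nM to 6000 nM.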

Compound 3, inhibition constant: 4000 nM
Estimate against measurement, compound 3: 2.7-fold (0.43 log units) below; low and high end bracket the measured number.
By their numbers in this assay, from the lowest: compound 1; then compounds 2 and 3 (each within the scatter of the next).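

In this assay the exchange of 2-hydroxyphenyl for 3-methoxyphenyl, on a saturated chain carbon two bonds along the chain from a carbonyl carbon, gives a 1.2-fold higher number from compound 2 to compound 3 (0.08 log units; within the scatter). The change removes the one hydrogen-bond donor counted on the leaving group and adds one carbon, yet the two compounds cannot be told apart in this assay, so at this position the two aryl tails read as equivalent. No supporting measurement accompanies the result to explain it.

The compounds shown do not separate the place of the oxygen from its capping, as 2-methoxyphenyl and 3-hydroxyphenyl would on the same chain. Going by these compounds, whether a chlorine on this tail, with the side chain of compound 2 kept, would reach the low number of compound 1 also stays open.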